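The source may report more compounds than this note shows. Statements on the series, on what has been measured and on what is new or still open speak of the compounds shown alone.

Compound 1 is `NC(=S)N1CCc2c(OCCCCCOc3ccc(Cl)cc3)cccc21`. In an ADME assay on Huh-7 cells (Homo sapiens) for cytotoxicity (on this read-out lower numbers stand for higher toxicity in this test and higher numbers for lower toxicity in this test), compound 1 reaches only the assay limit > 50000 nM.
Compound 2 is `NC(=S)n1ccc2c(OCCCCCOc3ccc(Cl)cc3)cccc21`. In this assay compound 2 gives 24700 nM.
Compound 3 is `O=C(NC(=S)N1CCc2c(OCCCCCOc3ccc(Cl)cc3)cccc21)Oc1ccccc1`. In this assay compound 3 reaches only the assay limit > 50000 nM.

Compound 3 therefore sits at the limit of > 50000 nM in this assay, at which 2 of the 3 values shown sit, so no exact number for it is known. Within the data shown here, the single measured step that touches compound 3, a step that the two limits leave unreadable from compound 1 to compound 3, cannot be read in size. Compound 4 is `O=C(NC(=S)N1CCc2c(OCCCCCOc3ccc(Cl)cc3)cccc21)c1cccc([N+](=O)[O-])c1`; it differs from compound 3 by 3-nitrophenyl in place of phenoxy on a carbonyl carbon. Among the measured compounds shown here, no measured step covers this change, and the step leading into compound 3 gives no size either. With nothing pointing to a change beyond the scatter, compound 4 is expected to stay near the limit, a step of a number no higher from compound 3 to compound 4 (the limit leaves the size open). The estimate for compound 4 in this assay is 50000 nM, with a range from 15000 nM to 100000 nM.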

Compound 4, half-maximal cytotoxic concentration: 12100 nM
Estimate against measurement, compound 4: 4.1-fold (0.62 log units) above, outside the stated range (below it).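

Putting 3-nitrophenyl in place of phenoxy on this carbonyl carbon moves the read-out in this assay off the limit, giving an at least 4.1-fold lower number from compound 3 to compound 4 (0.61 log units; beyond the scatter). On the amide-type nitrogen, (3-nitrophenyl)carbonyl in place of hydrogen gives an at least 4.1-fold lower number from compound 1 to compound 4 (0.61 log units; beyond the scatter), whereas the step with phenoxycarbonyl there cannot be read. Both sizes are only minimums because each step starts from a limit: the limit of > 50000 nM in this assay, at which 2 of the 4 values shown sit.

Still open, going by these compounds, is whether the nitro group matters or the loss of phenoxy alone does. A plain phenyl on the carbonyl, or an amine in place of the nitro group, would separate the two.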